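The source may report more compounds than this note shows. Statements on the series, on what has been measured and on what is new or still open speak of the compounds shown alone.

Measured compounds:
- compound 1 `N#CC1=C(N)Oc2c(N)cc3nc4ccccc4nc3c2C12C(=O)N(Cc1cnnn1-c1cccc(C(F)(F)F)c1)c1ccccc12`: in an ADME assay on L02 cells (Homo sapiens) for antiproliferative activity, read by MTT assay, with a stated time of 48 h (a higher number here means a weaker inhibitor, a lower number a stronger inhibitor), compound 1 gives 38100 nM.
- compound 2 `COc1ccccc1-n1nncc1CN1C(=O)C2(C(C#N)=C(N)Oc3c(N)cc4nc5ccccc5nc4c32)c2ccccc21`: in this assay compound 2 gives > 50000 nM, which is a limit of the assay and not a number.

Compound 2 thus stands at the limit of this assay, the limit recorded as the limit of > 50000 nM in this assay, at which 1 of the 2 values shown sits; where it lies beyond that is not known. For the measured compounds named here, the one measured step, an at least 1.3-fold higher number from compound 1 to compound 2 (0.11 log units; that floor lies within the scatter), concerns the aryl group on the aromatic nitrogen and sits at a floor within the scatter, so it gives no sign of a real change.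

Compound 3 `CCOc1ccccc1-n1nncc1CN1C(=O)C2(C(C#N)=C(N)Oc3c(N)cc4nc5ccccc5nc4c32)c2ccccc21` differs from compound 2 by methyl in place of hydrogen on a saturated chain carbon bound to an oxygen on an aromatic ring. Going by the values given here, no measured step touches the methoxy group itself, and the only step in hand is within the scatter. For compound 3 no step beyond the scatter is expected in this assay. The expected step is a step that the limit leaves unreadable from compound 2 to compound 3. Compound 3 is expected at 60000 nM, most likely again reported only as a limit. The expected range for compound 3 runs from 30000 nM to 150000 nM.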

Compound 3, half-maximal inhibitory concentration: > 50000 nM
Compound 3: only a limit was reported; the forecaster's own chance of this, stated with the estimate: 70%; the middle value does not contradict the limit.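

In this assay compound 3 gives > 50000 nM, which is a limit of the assay and not a number. Placing 2-ethoxyphenyl on the aromatic nitrogen in place of 3-(trifluoromethyl)phenyl gives an at least 1.3-fold higher number from compound 1 to compound 3 (0.11 log units; that floor lies within the scatter), so this change, like the one to 2-methoxyphenyl, gives no sign of a real change. Methoxy to ethoxy is the first change made on the alkoxy group itself, but its step cannot be read, and the new result adds a second compound at the same ceiling: the limit of > 50000 nM in this assay, at which 2 of the 3 values shown sit.

On these data alone, how far compound 2 and compound 3 lie beyond the limit, and whether they differ at all, stays open. Also open, as far as these compounds go, is whether a longer chain than ethoxy, an amine or a carboxylic acid at this place would give a value that can be read.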